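Terphenyl-benzimidazoles: hydroxy versus trifluoromethoxy on the end ring

The source may hold more compounds than are shown below. What is called first, only, known or untested is meant among the compounds shown, and "the series" means these compounds.

Measured so far in a functional assay on PC-3 cells (Homo sapiens) for inhibition, read by sulforhodamine B assay; on this read-out higher numbers stand for weaker inhibition of growth and lower numbers for stronger inhibition of growth:
compound 1, `FC(F)(F)Oc1ccc(-c2ccc(-c3ccc(-c4nc5ccccc5[nH]4)cc3)cc2)cc1`, 100000 nM
compound 2, `Oc1ccc(-c2ccc(-c3ccc(-c4nc5ccccc5[nH]4)cc3)cc2)cc1`, 47000 nM
compound 3, `Oc1cccc2[nH]c(-c3ccc(-c4ccc(-c5ccc(OC(F)(F)F)cc5)cc4)cc3)nc12`, 7410 nM

Compound 1 and compound 2 share a core and differ only at the far end of the chain of rings, where (hydrogen in place of trifluoromethyl on an oxygen on an aromatic ring). That single change gave a 2.1-fold lower number from compound 1 to compound 2 (0.33 log units; beyond the scatter) in this assay. Compound 3 differs from compound 1 in another place: hydroxy in place of hydrogen on an aromatic carbon, which produced the larger step of a 13-fold lower number from compound 1 to compound 3 (1.13 log units; beyond the scatter). Compound 3 therefore stands lowest of the three numbers, with compound 2 the nearer of the other two.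

Compound 4, `Oc1ccc(-c2ccc(-c3ccc(-c4nc5c(O)cccc5[nH]4)cc3)cc2)cc1`, has not yet been measured. It is related to compound 3 as compound 2 is to compound 1: hydrogen in place of trifluoromethyl on an oxygen on an aromatic ring. The place lines of the two changes read the same word for word, so this is the same change made on the core of compound 3 instead of the core of compound 1; how those two cores differ is given by hydroxy in place of hydrogen on an aromatic carbon.

Within the data shown here, the only precedent for this change is the step from compound 1 to compound 2, which was modest. Resting on that, the step from compound 3 to compound 4 in this assay is expected to be of a similar modest size, a 2.1-fold lower number from compound 3 to compound 4 (0.33 log units; beyond the scatter), because compound 1 gave 100000 nM and compound 2 gave 47000 nM. With compound 3 at 7410 nM, compound 4 is estimated at 3500 nM, with a likely range from 1500 nM to 9000 nM. Whether the two changes add in this way rests on one pair alone and remains to be seen.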

Compound 4, concentration for 50% growth inhibition: 190 nM
Beside the measured number, compound 4's estimate is 18-fold (1.27 log units) above it; measured number outside the range, below it.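

In this assay, the change from trifluoromethoxy to hydroxy lowers the number on both cores, but its size does not carry from one core to the other, and on the core of compound 3 it gives a 39-fold lower number from compound 3 to compound 4 (1.59 log units; beyond the scatter) against a much smaller step on the core of compound 1: the same change on two cores in this assay, a 2.1-fold lower number (0.33 log units; beyond the scatter) from compound 1 to compound 2 and a 39-fold lower number (1.59 log units; beyond the scatter) from compound 3 to compound 4, 18-fold (1.26 log units) apart, beyond the scatter of two such steps
Seen from the other side, the hydroxy on the aromatic carbon counts for more when the end ring carries hydroxy than when it carries trifluoromethoxy, giving a 250-fold lower number from compound 2 to compound 4 (2.39 log units; beyond the scatter) on that core: the same change on two cores in this assay, a 13-fold lower number (1.13 log units; beyond the scatter) from compound 1 to compound 3 and a 250-fold lower number (2.39 log units; beyond the scatter) from compound 2 to compound 4, 18-fold (1.26 log units) apart, beyond the scatter of two such steps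
In this set of compounds the two changes therefore do not simply add, although the direction of each holds on both cores, and four compounds cannot show why the steps differ or whether the same holds for any other pair of groups.

Still open, going by these compounds, is whether a free hydroxy is needed on the end ring, which a methoxy, an amine or a carboxylic acid in that place on the core of compound 3 would test. The same question stands for the hydroxy on the aromatic carbon of the shared core, where a methoxy or an amine would show whether the large gain in compound 4 depends on that hydroxy itself.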